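A Small Methyl Addition to Compound 2

The source may report more compounds than this note shows. Statements on the series, on what has been measured and on what is new or still open speak of the compounds shown alone.

Compound 1 `Cc1nnc(-c2nn(-c3ccccc3)c(-c3ccccc3)c2C#N)c2cn(-c3ccccc3)nc12`: 9140 nM
Compound 2 `N#Cc1c(-c2nnc(-c3ccccc3)c3nn(-c4ccccc4)cc23)nn(-c2ccccc2)c1-c1ccccc1`: 21800 nM
Compound 3 `Cc1ccc(-n2cc3c(-c4nn(-c5ccccc5)c(-c5ccccc5)c4C#N)nnc(-c4ccccc4)c3n2)cc1`: not yet measured

Going by the values given here, in a functional assay on T47D cells (Homo sapiens) for inhibition, read by sulforhodamine B assay, with a stated time of 48 h (on this read-out lower numbers stand for stronger inhibition of growth and higher numbers for weaker inhibition of growth), compound 2 gives 21800 nM, the higher of the two numbers so far, which makes it the weaker growth inhibitor of the measured pair. Compound 3 differs from it by a single change: methyl in place of hydrogen on an aromatic carbon. Put simply, this is methyl in place of hydrogen on an aromatic carbon, turning phenyl into 4-methylphenyl. Among the compounds with values here, only one measured step offers any guidance: a 2.4-fold higher number from compound 1 to compound 2 (0.38 log units; beyond the scatter). That modest step was a different swap, phenyl in place of methyl, so it says little about this change. Within the data shown here, with no direct precedent, no clear shift in either direction is expected. The expected step is a 1.1-fold lower number from compound 2 to compound 3 (0.04 log units; within the scatter). For compound 3, the estimated value is 20000 nM, with an expected range from 9000 nM to 45000 nM.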

Compound 3, concentration for 50% growth inhibition: 42600 nM
Compound 3: the middle estimate sits 2.1-fold (0.33 log units) below what was measured; the measured number falls inside the stated range.
By their numbers in this assay, from the lowest: compound 1; then compounds 2 and 3 (each within the scatter of the next).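

In this assay, turning phenyl into 4-methylphenyl gives a 2.0-fold higher number from compound 2 to compound 3 (0.29 log units; within the scatter), so this added methyl produces no difference that can be told apart from ordinary repeat-to-repeat variation. Going by these compounds alone, this is the first look at this position on this phenyl ring, since the earlier step between measured compounds involved a swap of methyl for phenyl at a different place on the shared core. No supporting measurement is available to explain this result.

One methyl is a very small probe, so the compounds shown leave open whether a larger or differently natured group at this position, such as an amine, a carboxylic acid or a longer chain, would move the number. They also leave open whether the same methyl would behave alike elsewhere on this phenyl ring.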